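Swapping the Formyl Group for Bromine on a Weak Inhibitor

The source may report more compounds than this note shows. Statements on the series, on what has been measured and on what is new or still open speak of the compounds shown alone.

Compound 1 `COn1c(-c2ccccc2)c(C=O)c2cc(C#N)c(C#N)cc21` is a weak inhibitor. In an assay on isolated protein for inhibition of Amine oxidase [flavin-containing] B (Homo sapiens), read by fluorescence and spectrophotometry, with a stated time of 20 min (a higher number here means a weaker inhibitor, a lower number a stronger inhibitor), compound 1 reaches only the assay limit of > 100000 nM, so no number is known for it. Compound 2 `COn1c(-c2ccc(C)cc2)c(C=O)c2cc(C#N)c(C#N)cc21` gives 74800 nM in this assay. Compound 3 `COc1ccc(-c2c(C=O)c3cc(C#N)c(C#N)cc3n2OC)cc1` also sits at a limit, > 100000 nM. Every measured step changes only the group on the phenyl ring: an at least 1.3-fold lower number from compound 1 to compound 2 (0.12 log units; that floor lies within the scatter), an at least 1.3-fold higher number from compound 2 to compound 3 (0.12 log units; that floor lies within the scatter) and a step that the two limits leave unreadable from compound 1 to compound 3, two of them bounded by the limit of > 100000 nM in this assay, at which 2 of the 3 values shown sit. Compound 4 `COn1c(-c2ccccc2)c(Br)c2cc(C#N)c(C#N)cc21` differs from compound 1 at another place: bromo in place of formyl on an aromatic carbon. Among the measured compounds shown here, no measured step touches that position, so they offer no direct guide to its size or direction. Compound 4 is therefore expected to remain near the limit, with a number no higher from compound 1 to compound 4 (the limit leaves the size open), an estimate of 100000 nM between 30000 nM and 300000 nM.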

Compound 4, half-maximal inhibitory concentration: > 100000 nM
Compound 4: only a limit was reported (the forecaster's own chance of this, stated with the estimate: 60%); the middle value lies on the limit itself.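

Among the compounds shown here, compound 4 gives > 100000 nM in this assay, which is a limit of the assay and not a number, so with compound 1 also at a limit, no step between them can be read. The compounds shown leave open whether bromo in place of formyl changes inhibition at all, and in which direction.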